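Methyl for Phenyl on the Ring Amine Nitrogen

The source may report more compounds than this note shows. Statements on the series, on what has been measured and on what is new or still open speak of the compounds shown alone.

Compound 2 `N#Cc1ccc(Nc2nc(Oc3ccnc4ccccc34)nc(N3CCN(c4ccccc4)CC3)n2)cc1C(F)(F)F` is one of three members of the series tested in a functional assay on DU-145 cells (Homo sapiens) for cytotoxicity, read by sulforhodamine B assay, with a stated time of 48 h; a lower number here means a stronger inhibitor of growth, a higher number a weaker inhibitor of growth. For compound 2 the result is a limit of the assay, > 100000 nM. Compound 1 `COc1ccc(CN2CCN(c3nc(Nc4ccc(C#N)c(C(F)(F)F)c4)nc(Oc4ccnc5ccccc45)n3)CC2)c(OC)c1OC` likewise returns only a limit, > 100000 nM. Compound 3 `N#Cc1ccc(Nc2nc(Oc3ccnc4ccccc34)nc(N3CCN(C(c4ccccc4)c4ccc(Cl)cc4)CC3)n2)cc1C(F)(F)F` also returns only a limit, > 100000 nM. Going by the values given here, every measured value therefore sits at the limit of > 100000 nM in this assay, at which 3 of the 3 values shown sit, and no step between measured compounds can be stated; where compound 2 stands relative to the others cannot be told beyond the shared limit.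

Compound 4 `CN1CCN(c2nc(Nc3ccc(C#N)c(C(F)(F)F)c3)nc(Oc3ccnc4ccccc34)n2)CC1` is not yet measured in this assay. It differs from compound 2 by methyl in place of phenyl on an amine nitrogen in a ring, that is, 4-phenylpiperazin-1-yl to 4-methylpiperazin-1-yl. No numeric starting point exists for this change, and the three measured compounds, differing widely at the same amine nitrogen, all fail to reach a measurable value. Compound 4 is expected to behave the same way, with a number no higher from compound 2 to compound 4 (the limit leaves the size open) estimated as no change beyond the scatter. The estimate for compound 4 in this assay is 100000 nM, ranging from 30000 nM to 300000 nM, most likely reported as a limit again.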

Compound 4, concentration for 50% growth inhibition: 51200 nM
For compound 4 the middle estimate is 2.0-fold (0.29 log units) above the measured one; the measured number falls inside the stated range.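

In this assay compound 4 gives 51200 nM, the only number among the compounds shown that is not a limit, so this amine nitrogen in a ring can carry a group that yields a measurable value. The phenyl to methyl change gives an at least 1.9-fold lower number from compound 2 to compound 4 (0.29 log units; that floor lies within the scatter), and the change of hydrogen in place of 2,3,4-trimethoxyphenyl on the saturated chain carbon gives an at least 1.9-fold lower number from compound 1 to compound 4 (0.29 log units; that floor lies within the scatter). Both steps are floors, so their true size stays unknown, and methyl is the only group at this nitrogen without a ring that is shown, with every ring-bearing group there ending at a limit: the limit of > 100000 nM in this assay, at which 3 of the 4 values shown sit.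

Open, from the compounds shown here alone, is whether ethyl, a longer chain or a hydroxyethyl group on this nitrogen would also give a number. Also open, going by these compounds, is whether any such group would move the value beyond the scatter.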